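Aryl hydrazone series: para substituent swap on compound 1

This account rests on a few compounds, and the source may have more. Where it says the series, first, only, none or still open, it means among the compounds named here.

Of the compounds shown here, three sharing one core have been measured in an assay on CHO-K1 cells for displacement of a labelled ligand from adenosine receptor A1 (Homo sapiens), read by scintillation counting, with a stated time of 60 min; a lower number here means a stronger inhibitor, a higher number a weaker inhibitor. Compound 1 `Nc1nc(N/N=C/c2ccc(OCc3ccc(F)cc3)cc2)nc2c1ncn2[C@@H]1O[C@H](CO)[C@@H](O)[C@H]1O` gives 70 nM and stands highest of the three numbers. Compound 2 `Nc1nc(N/N=C/c2ccc3ncccc3c2)nc2c1ncn2[C@@H]1O[C@H](CO)[C@@H](O)[C@H]1O` gives 9.8 nM, and compound 3 `N#Cc1ccccc1/C=N/Nc1nc(N)c2ncn([C@@H]3O[C@H](CO)[C@@H](O)[C@H]3O)c2n1` gives 2.9 nM, so compound 1 lies well above both. Within the data shown here, the only single-point step among them, a 3.4-fold lower number from compound 2 to compound 3 (0.53 log units; beyond the scatter), exchanges the whole aryl group on a carbon with a double bond to nitrogen.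

Compound 4 `Nc1nc(N/N=C/c2ccc(N3CCCC3)cc2)nc2c1ncn2[C@@H]1O[C@H](CO)[C@@H](O)[C@H]1O` differs from compound 1 by pyrrolidin-1-yl in place of (4-fluorobenzyl)oxy on an aromatic carbon. Among the measured compounds shown here, no measured step exchanges a substituent at this place. The step from compound 2 to compound 3 bears only indirectly, since it too varies the aryl group on that carbon, and it shows that such an exchange moves the number by a modest amount. Compounds 2 and 3, carrying different aryl groups from compound 1, both give lower numbers than compound 1, which suggests the (4-fluorobenzyl)oxy group is not needed for a low number. A lower number is therefore expected for compound 4, with a 4.7-fold lower number from compound 1 to compound 4 (0.67 log units; beyond the scatter), though without a direct precedent the range stays wide. Compound 4 is estimated at 15 nM, expected between 4 nM and 60 nM.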

Compound 4, inhibition constant: 5.1 nM
Beside the measured number, compound 4's estimate is 2.9-fold (0.47 log units) above it; the range from low to high includes it.
By their numbers in this assay, from the lowest: compounds 3, 4 and 2 (each within the scatter of the next, the first and the last beyond it); then compound 1.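

In this assay, among these compounds, the exchange on an aromatic carbon, para to a large group, gives the first direct reading at this place: pyrrolidin-1-yl in place of (4-fluorobenzyl)oxy brings a 14-fold lower number from compound 1 to compound 4 (1.14 log units; beyond the scatter) and is a large step, with the smaller group giving the lower number. The aryl comparisons then place compound 4 with the other two compounds, as a 1.8-fold higher number from compound 3 to compound 4 (0.25 log units; within the scatter) and a 1.9-fold lower number from compound 2 to compound 4 (0.28 log units; within the scatter) both lie within the scatter, so that 4-(pyrrolidin-1-yl)phenyl, 2-cyanophenyl and quinolin-6-yl cannot be told apart through compound 4, and among these four compounds only compound 1 stands clear of compound 4. Nothing available accounts for the size of this step.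

As far as these compounds go, whether the low number belongs to the pyrrolidine ring itself or to any small group on this carbon stays open, and a dimethylamino group, a morpholine ring or a methoxy group there would separate these readings. Also open, from the compounds shown here alone, is whether the high number of compound 1 goes with the fluorine or with the whole benzyl ether, which a plain benzyloxy group would address.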